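The source may hold more compounds than are shown below. What is called first, only, known or untested is meant among the compounds shown, and "the series" means these compounds.

Among the compounds with values here, compound 2 `Cn1cc(C2=C(c3nn(CCCCn4ccnc4)c4ncccc34)C(=O)N(c3ccccc3)C2=O)c2ccccc21` is the only compound of the set with a number in a functional assay on KB cells (Homo sapiens) for antiproliferative activity, read by MTT assay, with a stated time of 48 h; a higher number here means a weaker inhibitor, a lower number a stronger inhibitor: there compound 2 gives 47300 nM. Compound 1 `Cn1cc(C2=C(c3nn(CCCn4cccc4)c4ncccc34)C(=O)N(c3ccccc3)C2=O)c2ccccc21` gives in this assay only a limit, > 100000 nM. Within the data shown here, the one measured step, an at least 2.1-fold lower number from compound 1 to compound 2 (0.32 log units; beyond the scatter), is an at least modest gain, and it rests on (the limit of > 100000 nM in this assay, at which 1 of the 2 values shown sits), so its true size is not known.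

Compound 3 `Cn1cc(C2=C(c3nn(CCCn4cncn4)c4ncccc34)C(=O)N(c3ccccc3)C2=O)c2ccccc21` differs from compound 2 by 1H-1,2,4-triazol-1-yl in place of (1H-imidazol-1-yl)methyl on a saturated chain carbon, three bonds along the chain from an aromatic nitrogen. Among the measured compounds shown here, no measured step covers this change; the only step available concerns a different pair of groups and leaves the size of a change on the same chain position poorly defined. With compound 2 standing at 47300 nM, the account expects compound 3 to stay close to compound 2, with the step of a 1.2-fold higher number from compound 2 to compound 3 (0.07 log units; within the scatter) taken as an estimate lying within the usual scatter. Compound 3 is therefore estimated at 55000 nM, between 18000 nM and 160000 nM.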

Compound 3, half-maximal inhibitory concentration: > 100000 nM
Compound 3: only a limit was reported; the forecaster's own chance of this, stated with the estimate: 35%; middle value at least 1.8-fold (0.25 log units) away from the limit.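

In this assay compound 3 gives only a limit, > 100000 nM. Setting 3-(1H-1,2,4-triazol-1-yl)propyl in place of 4-(1H-imidazol-1-yl)butyl brings an at least 2.1-fold higher number from compound 2 to compound 3 (0.32 log units; beyond the scatter), so compound 2 remains the only compound with a number, and this position does respond to this change beyond the scatter. The step between compound 1 and compound 3 cannot be read, and the true size of the step above is not known: the limit of > 100000 nM in this assay, at which 2 of the 3 values shown sit.

Compound 2 alone carries both the butyl chain and the imidazole ring, and the compounds shown do not separate the part played by the chain from that of the ring. On these data alone, what 3-(1H-imidazol-1-yl)propyl, or an amine at the end of the butyl chain, would give in this assay also stays open.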